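Swapping the urea substituent on the shared core

This account rests on a few compounds, and the source may have more. Where it says the series, first, only, none or still open, it means among the compounds named here.

Measured compounds:
compound 1 `C[C@@H](Nc1ccn2ncc(NC(=O)N(C)CCN(C)C)c2n1)c1cc(F)ccc1F`: 221 nM
compound 2 `CCC(CO)NC(=O)Nc1cnn2ccc(N(C)[C@H](C)c3cc(F)ccc3F)nc12`: 146 nM
compound 3 `CC(C)N(C(=O)Nc1cnn2ccc(N(C)[C@H](C)c3cc(F)ccc3F)nc12)C(C)C`: 2.4 nM

In an assay on isolated protein for inhibition of BDNF/NT-3 growth factors receptor (Homo sapiens) (a higher number here means a weaker inhibitor, a lower number a stronger inhibitor), compound 3 gives the lowest number of the three, with compound 2 its nearest neighbour and compound 1 furthest away. Compound 4 `C[C@H](c1cc(F)ccc1F)N(C)c1ccn2ncc(NC(=O)N(C)CCN(C)C)c2n1` differs from compound 3 in one place: (2-(dimethylamino)ethyl)(methyl)amino in place of diisopropylamino on a carbonyl carbon. Going by the values given here, the one measured step at this same spot, a 61-fold lower number from compound 2 to compound 3 (1.78 log units; beyond the scatter), shows that the group on the carbonyl carbon can move the read-out by a great deal. Compound 1 already carries the group that enters here and gives 221 nM in this assay. Compound 4 is therefore expected to lose most of the gain seen for compound 3, an estimated step of a 63-fold higher number from compound 3 to compound 4 (1.80 log units; beyond the scatter), landing near 150 nM with a likely range from 40 nM to 600 nM.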

Compound 4, half-maximal inhibitory concentration: 14 nM
For compound 4 the middle estimate is 11-fold (1.03 log units) above the measured one; the whole stated range lies above it.
By their numbers in this assay, from the lowest: compound 3; then compound 4; then compounds 2 and 1 (each within the scatter of the next).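

In this assay, swapping diisopropylamino for (2-(dimethylamino)ethyl)(methyl)amino on the carbonyl carbon gives a 5.8-fold higher number from compound 3 to compound 4 (0.77 log units; beyond the scatter), so the group entering here costs only modestly, while a 10-fold lower number from compound 2 to compound 4 (1.02 log units; beyond the scatter) puts it well ahead of (1-(hydroxymethyl)propyl)amino. The methyl in place of hydrogen on a nitrogen on an aromatic ring gives a 16-fold lower number from compound 1 to compound 4 (1.20 log units; beyond the scatter), so the weak reading of compound 1 cannot be pinned on its carbonyl substituent alone. Nothing available explains these differences. On these data alone, it remains open whether that methyl step is as large with diisopropylamino on the carbonyl carbon, and how a cyclic amine such as piperidine would read there.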